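An Ester Side Chain Added to a Non-Toxic Core

This account rests on a few compounds, and the source may have more. Where it says the series, first, only, none or still open, it means among the compounds named here.

Compound 1 `Nc1ccc(-c2cc(=O)c3c(N)c(F)cc(F)c3o2)cc1F` is tested in a functional assay on HeLa cells (Homo sapiens) for cytotoxicity, read by neutral red uptake, with a stated time of 3 days; on this read-out higher numbers stand for weaker inhibition and lower numbers for stronger inhibition. In this assay compound 1 gives > 100000 nM, which is a limit of the assay rather than a number. Two close relatives share this outcome. Compound 2 `Cc1c(F)c(N)c2c(=O)cc(-c3ccc(N)c(F)c3)oc2c1F` carries methyl in place of hydrogen on an aromatic carbon, and in this assay compound 2 gives > 100000 nM, again a limit. Compound 3 `Nc1ccc(-c2cc(=O)c3c(N)c(F)c(Br)c(F)c3o2)cc1F` carries bromo in place of hydrogen on that aromatic carbon, and in this assay compound 3 gives > 100000 nM, also a limit. The steps between these three, a step that the two limits leave unreadable from compound 1 to compound 2, a step that the two limits leave unreadable from compound 1 to compound 3 and a step that the two limits leave unreadable from compound 2 to compound 3, therefore cannot be sized, since all three values sit at the limit of > 100000 nM in this assay, at which 3 of the 3 values shown sit.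

Compound 4 `CN(C)CCC(=O)OCc1c(F)c(N)c2c(=O)cc(-c3ccc(N)c(F)c3)oc2c1F` has not yet been measured. It differs from compound 1 by (((2-(dimethylamino)ethyl)carbonyl)oxy)methyl in place of hydrogen on an aromatic carbon. Within the data shown here, no measured step bears directly on this change, and the three measured steps at this carbon are all unreadable, so there is no sign from the data that substitution here moves the read-out in either direction. The expectation is that compound 4 also stays at the limit, so the step of a number no higher from compound 1 to compound 4 (the limit leaves the size open) is estimated to be essentially nothing. The estimate for compound 4 is 100000 nM, with a range from 30000 nM to 300000 nM.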

Compound 4, half-maximal inhibitory concentration: 11000 nM
For compound 4 the middle estimate is 9.1-fold (0.96 log units) above the measured one; the whole stated range lies above it.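

In this assay, among these compounds, this aromatic carbon turns out to be a place where a substituent can change the read-out: (((2-(dimethylamino)ethyl)carbonyl)oxy)methyl in place of hydrogen gives an at least 9.0-fold lower number from compound 1 to compound 4 (0.95 log units; beyond the scatter), the first step here that can be sized at all. The same group in place of bromo gives an at least 9.0-fold lower number from compound 3 to compound 4 (0.95 log units; beyond the scatter), and ((2-(dimethylamino)ethyl)carbonyl)oxy in place of hydrogen on a saturated chain carbon bound to an aromatic carbon gives an at least 9.0-fold lower number from compound 2 to compound 4 (0.95 log units; beyond the scatter). The steps among compound 1, compound 2 and compound 3 cannot be read, so hydrogen, methyl and bromo cannot be ranked against each other, and the three new steps give only a minimum size, as each starts from a limit: the limit of > 100000 nM in this assay, at which 3 of the 4 values shown sit.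

The compounds shown do not separate the parts of the side chain, so the lower number could go with the dimethylamino group, the ester link or the whole chain. Going by these compounds, a plain hydroxymethyl group, an amide in place of the ester, a longer chain before the amine or a carboxylic acid in place of the amine would each test a different part, and their effects remain open.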